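The compounds below may be only part of what the source reports. "The series", "measured", "known", "first", "only" and "open" are said of these compounds alone.

Working notes on the series in a functional assay on A549 cells (Homo sapiens) for cytotoxicity, read by MTT assay, with a stated time of 48 h; on this read-out lower numbers stand for stronger inhibition and higher numbers for weaker inhibition. Compound 1 `C=CC(=C)CC[C@@H]1[C@@]2(C)CCC[C@](C)(COC(=O)/C=C\c3ccc(O)cc3)[C@@H]2CC[C@@]1(C)O` gives 17100 nM in this assay. Compound 2 `C=CC(=C)CC[C@@H]1[C@@]2(C)CCC[C@](C)(COC(=O)/C=C/c3ccc(O)cc3)[C@@H]2CC[C@@]1(C)O` gives 20400 nM in this assay, the highest of the two numbers recorded, with compound 1 nearest. Between them the step is a 1.2-fold higher number from compound 1 to compound 2 (0.08 log units; within the scatter), which rests on the fact that compounds 1 and 2 differ only in the configuration as drawn and stays within the scatter. Compound 3 `C=CC(=C)[C@@H](O)C[C@H]1C(=C)CC[C@@H]2[C@]1(C)CCC[C@]2(C)C(=O)O` sits at the limit of > 40000 nM in this assay, at which 1 of the 3 values shown sits, reported as > 40000 nM, and this is a limit of the assay rather than a number.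

Compound 4 `C=CC(=C)CC[C@@H]1[C@@]2(C)CCC[C@](C)(COC(=O)/C=C/c3ccc(O)c(OC)c3)[C@@H]2CC[C@@]1(C)O` has not yet been measured in this assay. Relative to compound 2 the change is methoxy in place of hydrogen on an aromatic carbon, ortho to a hydroxy group. Within the data shown here, the only measured step, a 1.2-fold higher number from compound 1 to compound 2 (0.08 log units; within the scatter), concerns configuration as drawn, not substitution of the aromatic ring, so no measured step bears on this change. The step is therefore expected to be a 1.0-fold lower number from compound 2 to compound 4 (0.01 log units; within the scatter), none beyond the scatter. Compound 4 is estimated at 20000 nM, between 8000 nM and 45000 nM.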

Compound 4, half-maximal inhibitory concentration: 16800 nM
Estimate against measurement, compound 4: 1.2-fold (0.08 log units) above; measured number inside the range.
By their numbers in this assay, from the lowest: compounds 4, 1 and 2 (each within the scatter of the next). At a limit, above all of these: compound 3.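

In this assay the ring of the ester carries its first measured substitution: methoxy in place of hydrogen on the aromatic carbon ortho to a hydroxy group gives a 1.2-fold lower number from compound 2 to compound 4 (0.08 log units; within the scatter) and so leaves the number within the scatter at this position. The exchange of 2-(4-hydroxyphenyl)ethenyl for 2-(4-hydroxy-3-methoxyphenyl)ethenyl on the carbonyl carbon gives a 1.0-fold lower number from compound 1 to compound 4 (0.01 log units; within the scatter) and likewise stays within the scatter. Nothing available on these compounds bears on the reason for these two steps.

Going by these compounds, whether an ethoxy group or an amine at this same aromatic carbon would carry the number beyond the scatter remains open. Also open, on these data alone, is what happens when the hydroxy group itself is replaced, for instance by a methoxy group or a fluorine atom.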